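Removal of the ring-nitrogen allyl group in a diarylidene series

The source may report more compounds than this note shows. Statements on the series, on what has been measured and on what is new or still open speak of the compounds shown alone.

Three compounds of the shared core have been examined in a functional assay on BGC-823 cells (Homo sapiens) for cytotoxicity, read by CCK-8 assay, with a stated time of 72 h; on this read-out lower numbers stand for stronger inhibition and higher numbers for weaker inhibition. Compound 1 `COc1ccccc1/C=c1/[nH]c(=O)/c(=C\c2ccccc2OC)n(C)c1=O` is recorded as "not active" (no number reported), and compound 2 `COc1ccccc1/C=c1/[nH]c(=O)/c(=C\c2cccc(Cl)c2Cl)[nH]c1=O` is likewise recorded as "not active" (no number reported). For the measured compounds named here, compound 3 `C=CCn1c(=O)/c(=C\c2ccccc2OC)[nH]c(=O)/c1=C\c1ccccc1OC` is the only member with a number: in this assay compound 3 gives 13400 nM. Going by the values given here, compound 3 therefore stands as the sole quantified point, and no step between two measured compounds exists against which a structural change can be sized.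

Compound 4 `COc1ccccc1/C=c1/[nH]c(=O)/c(=C\c2ccccc2OC)[nH]c1=O` differs from compound 3 in one place: hydrogen in place of allyl on an aromatic nitrogen. The change leaves both aromatic nitrogens of the six-membered ring bearing hydrogen, a pattern that compound 2 shares, while compound 1 carries a methyl on one of them; neither of those two returned a number. Among the compounds with values here, there is no measured pair to anchor the size of this step, so the expectation rests on the weakness of compound 3 and on the absence of numbers for compounds 1 and 2. The step from compound 3 to compound 4 is expected to run toward weaker inhibition or to stay within the scatter, estimated as a 1.9-fold higher number from compound 3 to compound 4 (0.27 log units; within the scatter). For compound 4 the estimate in this assay is 25000 nM, within a range of 9000 nM to 80000 nM, with a substantial chance that no number is obtained.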

Compound 4, half-maximal inhibitory concentration: "not active" (no number reported)
For compound 4 the study gives words and no number; no gap can be computed for the estimate.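

Compound 4 is recorded in words only, so the step from compound 3, with hydrogen in place of allyl, cannot be read. Nothing available here bears on this result. The compounds shown leave open whether any change on the aromatic nitrogen can shift the 13400 nM of compound 3 in this assay.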